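A few compounds are considered here, and "the series" means these few. Any claim that something is new, unique, unknown or untested is made for them only; others in the source may bear on it.

In a functional assay on HeLa cells (Homo sapiens) for cytotoxicity, read by MTT assay (a lower number here means a stronger inhibitor, a higher number a weaker inhibitor), compound 1 `CC(C)=CC[C@@H](OC[C@H](C)O)C1=CC(=O)c2c(O)ccc(O)c2C1=O` gives 40300 nM, compound 2 `CC(=O)OCCO[C@H](CC=C(C)C)C1=CC(=O)c2c(O)ccc(O)c2C1=O` gives 41500 nM, and compound 3 `CC(C)=CC[C@@H](OC(=O)CC(C)(O)C(C)C)C1=CC(=O)c2c(O)ccc(O)c2C1=O` gives 27700 nM. These three values lie within the scatter of one another, so compound 3 holds no separate rank among them.

The still unmeasured compound 4 `CCCC(C)(O)CC(=O)O[C@H](CC=C(C)C)C1=CC(=O)c2c(O)ccc(O)c2C1=O` differs from compound 3 in one place only: propyl in place of isopropyl on a saturated chain carbon bound to an oxygen on a saturated carbon and two saturated chain carbons. The two have the same atoms, joined differently. Seen as a larger group, (2-hydroxy-2,3-dimethylbutyl)carbonyl becomes (2-hydroxy-2-methylpentyl)carbonyl.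

Among the measured compounds shown here, no measured step tests this exchange directly. The closest evidence comes from replacing the whole group on an oxygen on a saturated carbon, which gave a 1.5-fold lower number from compound 1 to compound 3 (0.16 log units; within the scatter) and a 1.5-fold lower number from compound 2 to compound 3 (0.18 log units; within the scatter). A change further out in the side chain of compound 2 gave a 1.0-fold higher number from compound 1 to compound 2 (0.01 log units; within the scatter). All three steps stay within the scatter, so no step beyond the scatter is expected in this assay, and no direction is favoured. The expected step is a 1.0-fold higher number from compound 3 to compound 4 (0.00 log units; within the scatter). Compound 4 is estimated at 28000 nM, with an expected range from 16000 nM to 48000 nM.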

Compound 4, half-maximal inhibitory concentration: 72000 nM
For compound 4 the middle estimate is 2.6-fold (0.41 log units) below the measured one; the whole stated range lies below it.
By their numbers in this assay, from the lowest: compounds 3, 1, 2 and 4 (each within the scatter of the next, the first and the last beyond it).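

In this assay, among the compounds shown here, propyl in place of isopropyl on a saturated chain carbon bound to an oxygen on a saturated carbon and two saturated chain carbons gives a 2.6-fold higher number from compound 3 to compound 4 (0.41 log units; beyond the scatter), the only step in this set that passes the scatter, and it comes from an exchange in which the same atoms are joined differently. This position therefore responds to how the three carbons of this end group are arranged, even though no atom is added or lost. Compound 4 is not set apart from the two compounds with the smaller side chains, as a 1.7-fold higher number from compound 2 to compound 4 (0.24 log units; within the scatter) and a 1.8-fold higher number from compound 1 to compound 4 (0.25 log units; within the scatter) both stay within the scatter, so the change shows up only against compound 3. Nothing measured here offers an explanation for the step.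

On these data alone, only these two arrangements of the end group are compared at this position, so it remains open whether the step belongs to the isopropyl group alone or would recur with other branched groups. The compounds shown also do not tell how a longer chain such as butyl, or an amine at the end of the propyl group, would read in this assay.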